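Pyrazine methyl removal on two quinoline amide cores

This account rests on a few compounds, and the source may have more. Where it says the series, first, only, none or still open, it means among the compounds named here.

In a functional assay on PANC-1 cells (Homo sapiens) for inhibition, read by MTT assay, with a stated time of 72 h (on this read-out higher numbers stand for weaker inhibition and lower numbers for stronger inhibition), compound 1 `Cc1cnc(C(=O)Nc2cccc3ccc(C)nc23)cn1` gives only a limit of the assay, > 10000 nM. Compound 3 `Cc1ccc2cccc(NC(=O)c3cnccn3)c2n1` also gives only a limit in this assay, > 10000 nM. Compound 3 differs from compound 1 by hydrogen in place of methyl on an aromatic carbon. The step that the two limits leave unreadable from compound 1 to compound 3 cannot be read because of the limit of > 10000 nM in this assay, at which 2 of the 3 values shown sit, so from this pair the size of the change is not known.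

Compound 2 `Cc1cnc(C(=O)Nc2cc(F)cc3cccnc23)cn1` carries a different core; the difference between the core of compound 1 and the core of compound 2 is not broken down here. In this assay, within the data shown here, compound 2 gives 2100 nM, the only number among the three measured compounds.

Compound 4 `O=C(Nc1cc(F)cc2cccnc12)c1cnccn1` has not been measured in this assay. It differs from compound 2 by hydrogen in place of methyl on an aromatic carbon. Among the measured compounds shown here, this is the same change as the one from compound 1 to compound 3, at the same kind of place, with the pyrazine again attached through the amide to a quinoline bearing the fluorine in compound 2 and compound 4. For the measured compounds named here, since the only measured instance of this change is unreadable, no direction is established for it, and an expected step of a 1.4-fold higher number from compound 2 to compound 4 (0.15 log units; within the scatter), close to no change, rests on the single measured value of compound 2 2100 nM rather than on the unreadable pair. Compound 4 is therefore expected to give about 3000 nM in this assay. For compound 4 the expected range runs from 800 nM to 12000 nM, wide because the parallel step that the two limits leave unreadable from compound 1 to compound 3 gives no size.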

Compound 4, half-maximal inhibitory concentration: 670 nM
Compound 4: middle estimate off by 4.5-fold (0.65 log units), on the high side; measured number below the stated range.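

In this assay, the change from 5-methylpyrazin-2-yl to pyrazin-2-yl on the core of compound 2 gives a 3.1-fold lower number from compound 2 to compound 4 (0.50 log units; beyond the scatter), so on this core the read-out moves toward stronger inhibition when the methyl leaves. Among these compounds, the same change on the core of compound 1 cannot be read, because compound 1 and compound 3 both stand at a limit of the assay and not at a number: the limit of > 10000 nM in this assay, at which 2 of the 4 values shown sit. With only one readable instance, on a single core, the step shows what this change does on the core of compound 2 but does not show that it carries over to the core of compound 1, in either direction or size, and it gives no reason for the shift.

Still open, as far as these compounds go, is whether an amine, a methoxy group or a longer chain such as propyl, set where compound 2 carries its methyl, would keep, extend or reverse the step seen on this core. Among the compounds shown here, also open is how the methyl and the fluorine on the two cores each contribute, as the core of compound 1 and the core of compound 2 differ in more than one place and no pair here separates them.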